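A few compounds are considered here, and "the series" means these few. Any claim that something is new, unique, unknown or untested is made for them only; others in the source may bear on it.

Measured compounds:
Compound 1 `COc1cc2ncnc(Nc3cccc(Cl)c3)c2cc1B1OC(C)(C)C(C)(C)O1` — in an assay on isolated protein for inhibition of vascular endothelial growth factor receptor 1 (Homo sapiens), read by ELISA, with a stated time of 20 min (a higher number here means a weaker inhibitor, a lower number a stronger inhibitor), compound 1 gives > 1000 nM, a limit of the assay rather than a number.
Compound 2 `OB(O)c1ccc2ncnc(Nc3cccc(Cl)c3)c2c1` — in this assay compound 2 gives > 1000 nM, again a limit of the assay rather than a number.

Compound 2 therefore stands nowhere in particular on the numbers shown: it has no measured value of its own, only a limit, and the other value shown is a limit as well. Both measurements sit at the same place, (the limit of > 1000 nM in this assay, at which 2 of the 2 values shown sit), so the two structures cannot be ranked against each other; the data show only that neither reached the range the assay can report.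

Compound 3 `COc1cc2ncnc(Nc3cccc(Cl)c3)c2cc1B(O)O` differs from compound 2 in a single place: methoxy in place of hydrogen on an aromatic carbon. No measured step of this kind exists among the compounds shown, so the expectation rests on the two limits alone. With both measured values at the limit, the step that the limit leaves unreadable from compound 2 to compound 3 is estimated to bring no change beyond the scatter. Compound 3 is thus expected to give roughly 2000 nM in this assay, with a likely range from 500 nM to 10000 nM.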

Compound 3, half-maximal inhibitory concentration: > 1000 nM
Compound 3: a limit, no number; the forecaster's own chance of this, stated with the estimate: 75%; the middle value lies beyond the limit too.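

In this assay compound 3 gives > 1000 nM, a limit of the assay and not a number. Among these compounds, no step from compound 1 or compound 2 to compound 3 can be read, since all three share the same limit: the limit of > 1000 nM in this assay, at which 3 of the 3 values shown sit. The compounds shown leave open how strongly each one inhibits, and whether methoxy in place of hydrogen changes that at all.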